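The source may hold more compounds than are shown below. What is called first, only, known or untested is meant among the compounds shown, and "the series" means these compounds.

Measured in a functional assay on HCT-116 cells (Homo sapiens) for inhibition, read by MTT assay, with a stated time of 48 h; a lower number here means a stronger inhibitor, a higher number a weaker inhibitor:
- compound 1 `COCC(=O)N(Cc1ccc(OC)c(O)c1)c1cc(OC)c(OC)c(OC)c1`: 230 nM
- compound 2 `C#CC(=O)N(Cc1ccc(OC)c(O)c1)c1cc(OC)c(OC)c(OC)c1`: 310 nM
- compound 3 `COc1ccc(CN(C(=O)CN=[N+]=[N-])c2cc(OC)c(OC)c(OC)c2)cc1O`: 410 nM

Compound 3 stands within the scatter of both other compounds: a 1.3-fold higher number from compound 2 to compound 3 (0.12 log units; within the scatter), and a 1.8-fold higher number from compound 1 to compound 3 (0.25 log units; within the scatter). The next compound is compound 4 `COc1ccc(CN(C(=O)CCCl)c2cc(OC)c(OC)c(OC)c2)cc1O`. Its difference from compound 3 is chloromethyl in place of azido on a saturated chain carbon bound to a carbonyl carbon. In words, this is chloromethyl in place of azido on a saturated chain carbon bound to a carbonyl carbon, which turns azidomethyl into 2-chloroethyl.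

Among the compounds with values here, the two steps above bear on this change, the one between compound 1 and compound 3 most closely, since it alters the same place. The remaining measured step is a 1.3-fold higher number from compound 1 to compound 2 (0.13 log units; within the scatter). Within the data shown here, all three changes stay within the scatter, but no compound carrying chlorine has been measured, so the guidance is indirect. No step beyond the scatter is expected in this assay, and no direction is firmly indicated. The expected step is a 1.3-fold lower number from compound 3 to compound 4 (0.11 log units; within the scatter). For compound 4 the estimated value is 320 nM, with an expected range of 130 nM to 800 nM.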

Compound 4, half-maximal inhibitory concentration: 150 nM
The estimate for compound 4 lay 2.1-fold (0.33 log units) above the measured number, and the stated range covers the measured number.
By their numbers in this assay, from the lowest: compounds 4, 1, 2 and 3 (each within the scatter of the next, the first and the last beyond it).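

In this assay, within the data shown here, the 2-chloroethyl group on the carbonyl carbon gives the first steps in this set that pass the scatter (a 2.7-fold lower number from compound 3 to compound 4 (0.44 log units; beyond the scatter); a 2.1-fold lower number from compound 2 to compound 4 (0.32 log units; beyond the scatter)), whereas every earlier step stayed within it. The same change does not separate compound 4 from the methoxymethyl-bearing compound 1 (a 1.5-fold lower number from compound 1 to compound 4 (0.19 log units; within the scatter)), so the modest gain holds against the azidomethyl and ethynyl groups only. Nothing at hand explains the step from azido to chloromethyl on the saturated chain carbon bound to a carbonyl carbon.

Open, as far as these compounds go, is whether chlorine itself carries the step, which a plain ethyl or a 2-bromoethyl group at this place would test. Also open, from the compounds shown here alone, is how a longer chain, such as 3-chloropropyl, or a chain ending in an amine would read in this assay against compound 4.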